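Methoxymethyl in place of methylsulfanyl on the aromatic ring

The source may report more compounds than this note shows. Statements on the series, on what has been measured and on what is new or still open speak of the compounds shown alone.

In a functional assay on KB cells (Homo sapiens) for antiproliferative activity, read by sulforhodamine B assay, with a stated time of 3 days (a lower number here means that less compound is needed, a higher number that more compound is needed for the effect), compound 1 `CCCc1ccc(-c2cc(=O)c3c(o2)C(CC)(CC)C(=O)C(CC)=C3O)cc1` gives > 53 uM, which is a limit. Compound 2 `CCC1=C(O)c2c(oc(-c3ccc(SC)cc3)cc2=O)C(CC)(CC)C1=O` gives > 52.1 uM, also a limit, so it has no readable number. Going by the values given here, the only measured step is a step that the two limits leave unreadable from compound 1 to compound 2, and it was methylsulfanyl in place of propyl. Compound 3 `CCC1=C(O)c2c(oc(-c3ccc(COC)cc3)cc2=O)C(CC)(CC)C1=O` carries methoxymethyl in place of methylsulfanyl on an aromatic carbon, para to a large group: methoxymethyl in place of methylsulfanyl on an aromatic carbon. Among the compounds with values here, no measured step indicates a gain in this assay, so no change beyond the scatter is expected in either direction. The expected step is a number no higher from compound 2 to compound 3 (the limit leaves the size open). For compound 3 the estimated value is 52 uM, with an expected range of 25 uM to 100 uM.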

Compound 3, concentration for half-maximal effect: > 52.4 uM
Compound 3 ended at the assay's limit; the forecaster's own chance of this, stated with the estimate: 85%; at least 1.0-fold (0.00 log units) between middle value and limit.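

Going by these compounds alone, compound 3, like compound 1 and compound 2, gives only a limit, so no step among them can be read. The compounds shown leave open whether propyl, methylsulfanyl or methoxymethyl on the aromatic carbon changes the value in this assay at all.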